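The source may hold more compounds than are shown below. What is called first, only, known or untested is meant among the compounds shown, and "the series" means these compounds.

Measured so far:
compound 1 `C=Cc1ccccc1C1C(C(=O)OC)=C(C)N=C(C)/C1=C(\O)OC` — 4.47 nM
compound 2 `COC(=O)C1=C(C)N=C(C)/C(=C(\O)OC)C1c1ccc(I)cc1` — 22900 nM
compound 3 `COC(=O)C1=C(C)N=C(C)/C(=C(\O)OC)C1c1cccc(I)c1` — 41.7 nM

All three share one core and differ only in the aryl group attached to a saturated ring carbon, and all were tested in a functional assay (muscle tissue) with Cavia porcellus as the target; on this read-out higher numbers stand for an effect only at larger amounts of compound and lower numbers for an effect already at smaller amounts. Among these three numbers compound 3 stands second highest: compound 1 lies nearest, with a 9.3-fold higher number from compound 1 to compound 3 (0.97 log units; beyond the scatter), and compound 2 lies furthest, with a 550-fold lower number from compound 2 to compound 3 (2.74 log units; beyond the scatter).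

Compound 4 `COC(=O)C1=C(C)N=C(C)/C(=C(\O)OC)C1c1ccc(C#N)cc1` is not yet measured. It differs from compound 3 in one place: 4-cyanophenyl in place of 3-iodophenyl on a saturated ring carbon. The change therefore does two things at once, moving the substituent from the 3-position to the 4-position of the phenyl ring and swapping iodine for a nitrile. Only the first part has a precedent. The step of a 550-fold lower number from compound 2 to compound 3 (2.74 log units; beyond the scatter) shows how strongly a 3-iodophenyl is favoured over a 4-iodophenyl on this core, and a 5100-fold higher number from compound 1 to compound 2 (3.71 log units; beyond the scatter) shows that a 4-iodophenyl is by far the weakest of the measured aryl groups. Within the data shown here, no measured pair speaks to iodine against nitrile, so that part is unknown.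

On that basis a large rise in the number is expected for compound 4, a 360-fold higher number from compound 3 to compound 4 (2.56 log units; beyond the scatter), with compound 2 as the closest guide, and compound 4 is estimated at 15000 nM (range 1500 nM to 100000 nM).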

Compound 4, half-maximal effective concentration: 3470 nM
Compound 4: the middle estimate sits 4.3-fold (0.64 log units) above what was measured; low and high end bracket the measured number.
By their numbers in this assay, from the lowest: compound 1; then compound 3; then compound 4; then compound 2.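

Among these compounds, compound 2 and compound 4 differ only in the atom or group carried on the phenyl ring, so this pair gives the first direct reading of nitrile against iodine: in this assay, the change brings a 6.6-fold lower number from compound 2 to compound 4 (0.82 log units; beyond the scatter). The group on the phenyl ring therefore matters in its own right, and not only where it sits. Even so, the 4-cyanophenyl stays far from the other two aryl groups, with an 83-fold higher number from compound 3 to compound 4 (1.92 log units; beyond the scatter) and a 780-fold higher number from compound 1 to compound 4 (2.89 log units; beyond the scatter), which leaves the 4-iodophenyl and 4-cyanophenyl compounds with the two highest numbers of the four. Nothing measured here explains these differences.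

From the compounds shown here alone, because compound 3 and compound 4 change both the group and its place on the phenyl ring, it remains open whether a 3-cyanophenyl would gain over the 4-cyanophenyl as the 3-iodophenyl gains over the 4-iodophenyl. Also open, going by these compounds, is how a 2-cyanophenyl or 2-iodophenyl would compare with the 2-vinylphenyl, and whether an amine or a carboxylic acid on the phenyl ring would fit the same order.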